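Adding a difluoroethyl group to compound 2

A few compounds are considered here, and "the series" means these few. Any claim that something is new, unique, unknown or untested is made for them only; others in the source may bear on it.

Compound 2 `O=C(NCCCCc1ccccc1)c1cccc(C2SCC(=O)N2c2ccccc2)c1` gives 73% in a functional assay on SJSA-1 cells (Homo sapiens) for inhibition, read by CCK-8 assay, with a stated time of 72 h, tested at 1 uM (a lower number here means less inhibition, a higher number more inhibition at the concentration tested (going by the name of the read-out)), the highest of the two numbers measured. For the measured compounds named here, its only neighbour is compound 1 `COc1c(F)cccc1N1C(=O)CSC1c1cccc(C(=O)NCCCCc2ccccc2)c1`, which in this assay gives 1%; the step of a number 72 percentage points higher from compound 1 to compound 2 (beyond the scatter) is the one large movement in this set. Compound 3 `CC(F)(F)c1cccc(N2C(=O)CSC2c2cccc(C(=O)NCCCCc3ccccc3)c2)c1` has not yet been measured. It differs from compound 2 by 1,1-difluoroethyl in place of hydrogen on an aromatic carbon. Going by the values given here, no measured pair adds a single group to an aromatic ring in this way, so the step from compound 2 to compound 3 has no direct precedent. What the data do show is that the step of a number 72 percentage points higher from compound 1 to compound 2 (beyond the scatter) changed the substitution of an aromatic ring and moved the number far beyond the scatter, so a substituent on such a ring can matter greatly here, and the bare ring of compound 2 gave the higher value. For compound 3 a decrease is therefore expected, of a size given by a number 23 percentage points lower from compound 2 to compound 3 (beyond the scatter), with wide uncertainty. The estimate for compound 3 in this assay is 50%, within a range from 20% to 80%.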

Compound 3, a percentage reported as inhibition, at one concentration (the size of the read-out at that concentration, not a potency): 68%
Compound 3: middle estimate off by 18 percentage points, on the low side; measured number inside the range.
By their numbers in this assay, from the lowest: compound 1; then compounds 3 and 2 (each within the scatter of the next).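

In this assay, the 1,1-difluoroethyl group on an aromatic carbon, meta to a large group, leaves the number level with that of the bare ring, a number 5 percentage points lower from compound 2 to compound 3 (within the scatter), so this position accepts a substituent without a change that can be told from the scatter. The step of a number 67 percentage points higher from compound 1 to compound 3 (beyond the scatter) exchanges one substituted phenyl on the amide-type nitrogen in a ring for another, which shows that the low number of compound 1 does not follow from substitution of this ring as such; what matters is which groups it carries and where they stand. No measurement is available here that bears on why these two substituted rings give such different numbers.

The compounds shown leave open whether the 3-fluoro-2-methoxyphenyl of compound 1 owes its low number to the methoxy group, to the fluorine or to the two together, as neither is seen alone on the ring. They also leave open whether the number would be higher, lower or level with other groups at this position, such as an amine, a carboxylic acid or a longer chain, in place of the 1,1-difluoroethyl group of compound 3.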